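Compound 3: methoxy in place of chloro

This account rests on a few compounds, and the source may have more. Where it says the series, first, only, none or still open, it means among the compounds named here.

In a functional assay, read by spectrophotometry, tested at 100 uM (on this read-out lower numbers stand for stronger inhibition and higher numbers for weaker inhibition), compound 1 (`O=C(/C=C/c1ccccc1)c1cccc(NC(=O)c2cc(-c3ccncc3)n[nH]2)c1`) gives 67100 nM and compound 2 (`O=C(/C=C/c1ccccc1Cl)c1cccc(NC(=O)c2cc(-c3ccncc3)n[nH]2)c1`) gives 27700 nM as the lower of the two numbers. Going by the values given here, the only measured step is a 2.4-fold lower number from compound 1 to compound 2 (0.38 log units; beyond the scatter) with chloro in place of hydrogen on an aromatic carbon, and it is modest.

Compound 3 (`COc1ccccc1/C=C/C(=O)c1cccc(NC(=O)c2cc(-c3ccncc3)n[nH]2)c1`) carries methoxy in place of chloro on an aromatic carbon, ortho to a large group (methoxy in place of chloro on an aromatic carbon) so that 2-chlorophenyl becomes 2-methoxyphenyl. Among the compounds with values here, the series holds no methoxy compound yet, so that single step is the only guide. The lower number of compound 2 at 27700 nM came with chloro and need not carry over to methoxy. A step no larger than the measured one is therefore expected in this assay, leaning towards a higher number and possibly staying within the scatter. The estimate means a 1.4-fold higher number from compound 2 to compound 3 (0.16 log units; within the scatter) as the expected change. For compound 3 the estimated value is 40000 nM with 15000 nM to 90000 nM as the expected range.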

Compound 3, half-maximal inhibitory concentration: 41700 nM
The estimate for compound 3 lay 1.0-fold (0.02 log units) below the measured number; the measured number falls inside the stated range.
By their numbers in this assay, from the lowest: compounds 2, 3 and 1 (each within the scatter of the next, the first and the last beyond it).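

In this assay, the place on the aromatic ring that holds chloro in compound 2 also accepts methoxy with a 1.5-fold higher number from compound 2 to compound 3 (0.18 log units; within the scatter), so these two groups are not separated on this read-out. Against hydrogen at the same place, methoxy gives a 1.6-fold lower number from compound 1 to compound 3 (0.21 log units; within the scatter), whereas chloro gives a 2.4-fold lower number from compound 1 to compound 2 (0.38 log units; beyond the scatter); only the chloro step therefore clears the scatter, although compound 2 and compound 3 themselves remain within it. No supporting measurement bears on why these values fall as they do.

The compounds shown leave open whether any group at this place can move the number clearly beyond the span set by hydrogen, chloro and methoxy, for example an amine, a carboxylic acid or a longer chain such as ethoxy. They also leave open whether chloro and methoxy would read the same way at another carbon of this ring, or on a changed version of the shared core.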